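The source may report more compounds than this note shows. Statements on the series, on what has been measured and on what is new or still open speak of the compounds shown alone.

Series notes: the shared core of compound 1 `O=C(O)c1cc(-c2cccc(COc3ccc4c(c3)CN(Cc3ccc(C(F)(F)F)cc3)C4=O)c2)ccc1Cl` carries a substituent on the amide-type nitrogen of its five-membered ring, and the three measured compounds differ only there. In an assay on HEK293 cells for positive allosteric modulation of metabotropic glutamate receptor 2 (Rattus norvegicus), read by thallium flux (on this read-out lower numbers stand for smaller maximal responses and higher numbers for larger maximal responses), compound 1 gives 86.7%. Compound 2 `CC(C)CN1Cc2cc(OCc3cccc(-c4ccc(Cl)c(C(=O)O)c4)c3)ccc2C1=O` gives 63.9%, and compound 3 `CC(C)CCN1Cc2cc(OCc3cccc(-c4ccc(Cl)c(C(=O)O)c4)c3)ccc2C1=O` gives 85.3%. Compound 3 thus stands second highest of the three numbers: its step from compound 1 is small, a number 1.4 percentage points lower from compound 1 to compound 3 (within the scatter), while against compound 2 the gap is clear, a number 21.4 percentage points higher from compound 2 to compound 3 (beyond the scatter). The other measured step runs the same way, a number 22.8 percentage points lower from compound 1 to compound 2 (beyond the scatter), so within this small set the isopropyl compound sits apart from the two larger substituents.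

Compound 4 `O=C(O)c1cc(-c2cccc(COc3ccc4c(c3)CN(C3CC3)C4=O)c2)ccc1Cl` differs from compound 3 by cyclopropyl in place of isopentyl on an amide-type nitrogen in a ring. Going by the values given here, the steps that bear on it are those between the isopropyl, isobutyl and 4-(trifluoromethyl)phenyl compounds, each of modest size where the group shrinks. Cyclopropyl is the smallest group in the set by its count, so a downward step beyond the scatter is expected, of the order seen for compound 2, giving an estimated a number 17.3 percentage points lower from compound 3 to compound 4 (beyond the scatter). Compound 4 is therefore expected to reach about 68%, with a range from 54% to 84%.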

Compound 4, largest response reached (Emax), in percent of the reference or control that the assay uses: 64.9%
The estimate for compound 4 lay 3.1 percentage points above the measured number; low and high end bracket the measured number.
By their numbers in this assay, from the lowest: compounds 2 and 4 (each within the scatter of the next); then compounds 3 and 1 (each within the scatter of the next).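

In this assay, the step of a number 1 percentage points higher from compound 2 to compound 4 (within the scatter) puts the cyclopropyl ring on the amide-type nitrogen level with the open isobutyl chain, so a ring at this position and a branched chain of this kind cannot be told apart on maximal response. The steps of a number 20.4 percentage points lower from compound 3 to compound 4 (beyond the scatter) and a number 21.8 percentage points lower from compound 1 to compound 4 (beyond the scatter) then separate compound 4 from both the isopentyl and the 4-(trifluoromethyl)benzyl compounds, and the four compounds now fall into two levels, with compounds 2 and 4 in the lower and compounds 1 and 3 in the upper. The lower level therefore no longer rests on compound 2 alone, though no accompanying measurement accounts for the split between the two levels.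

The compounds shown do not fix where the change between levels falls, which a cyclobutyl or cyclopentyl ring, or an unbranched butyl chain, on the same nitrogen could help to place. They also leave open whether a chain longer than isopentyl holds the upper level, and how a chain ending in an amine or a hydroxyl group would compare.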